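Trifluoromethyl in place of hydroxymethyl on compound 2

A few compounds are considered here, and "the series" means these few. Any claim that something is new, unique, unknown or untested is made for them only; others in the source may bear on it.

- compound 1 `CNC(=O)c1cc(N)c(Nc2ccc(C#N)cc2)cc1Oc1c(C)cc(CCC#N)cc1C` gives 120 mL.min-1.g-1
- compound 2 `Cc1cc(CCC#N)cc(C)c1Oc1cc(Nc2ccc(C#N)cc2)c(N)cc1CO` gives 330 mL.min-1.g-1

In an in vitro ADME assay on microsomes from liver (Homo sapiens) for metabolic stability, tested at 1 uM (on this read-out higher numbers stand for fast clearance and lower numbers for slow clearance), compound 2 has the higher of the two numbers, 330 mL.min-1.g-1. The next structure, compound 3 `Cc1cc(CCC#N)cc(C)c1Oc1cc(Nc2ccc(C#N)cc2)c(N)cc1C(F)(F)F`, carries trifluoromethyl in place of hydroxymethyl on an aromatic carbon. Among the measured compounds shown here, one measured step bears on this carbon, a 2.8-fold higher number from compound 1 to compound 2 (0.44 log units; beyond the scatter), a modest change beyond the scatter. It involves a different pair of groups and gives no direction for the new change. No step beyond the scatter is therefore expected in this assay. The estimate for compound 3 is 280 mL.min-1.g-1, with an expected range of 120 mL.min-1.g-1 to 600 mL.min-1.g-1. This estimate means a 1.2-fold lower number from compound 2 to compound 3 (0.07 log units; within the scatter).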

Compound 3, intrinsic clearance in microsomes: 120 mL.min-1.g-1
The estimate for compound 3 lay 2.3-fold (0.37 log units) above the measured number, and the stated range covers the measured number.
By their numbers in this assay, from the lowest: compounds 1 and 3 (each within the scatter of the next); then compound 2.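

In this assay, the new result singles out hydroxymethyl at this carbon: replacing it with trifluoromethyl lowers the number (a 2.8-fold lower number from compound 2 to compound 3 (0.44 log units; beyond the scatter)), while trifluoromethyl and methylcarbamoyl cannot be told apart (no change at the digits printed from compound 1 to compound 3 (within the scatter)). Of these three groups, only hydroxymethyl gives the higher number, so two quite different groups share the lower level. Nothing available explains why compound 2 stands apart.

As far as these compounds go, it remains open whether a methoxy group or a carboxylic acid on this carbon would match hydroxymethyl or the other two groups. From the compounds shown here alone, it is also open whether a longer chain, such as hydroxyethyl, would keep the higher number.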